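A few compounds are considered here, and "the series" means these few. Any claim that something is new, unique, unknown or untested is made for them only; others in the source may bear on it.

Compound 1 `COc1nc(Cl)nc2c1ncn2[C@H]1C[C@H](N=[N+]=[N-])[C@@H](CO)O1` was tested in an ADME assay on CCRF-CEM cells (Homo sapiens) for cytotoxicity, with a stated time of 5 days; on this read-out lower numbers stand for stronger inhibition and higher numbers for weaker inhibition. Compound 1 reaches only the limit of the measurement, > 100000 nM. Compound 2 `COc1nc(OC)c2ncn([C@H]3C[C@H](N=[N+]=[N-])[C@@H](CO)O3)c2n1` differs from it by methoxy in place of chloro on an aromatic carbon. Compound 2 likewise stops at the limit, > 100000 nM. The step that the two limits leave unreadable from compound 1 to compound 2 therefore cannot be sized, because of the limit of > 100000 nM in this assay, at which 2 of the 2 values shown sit. Compound 3 `[N-]=[N+]=N[C@H]1C[C@H](n2cnc3c(NC4CC4)nc(Cl)nc32)O[C@@H]1CO` changes compound 1 elsewhere: cyclopropylamino in place of methoxy on an aromatic carbon. Going by the values given here, no measured step resembles this change, and the single step that exists yields no number, so compound 1 stands only at a limit and nothing shows whether cyclopropylamino moves it beyond the scatter in either direction. The estimate for compound 3 in this assay is 100000 nM, expected to fall between 30000 nM and 300000 nM, near the same limit. That estimate means an expected step of a number no higher from compound 1 to compound 3 (the limit leaves the size open).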

Compound 3, half-maximal inhibitory concentration: > 100000 nM
Compound 3 ended at the assay's limit (the forecaster's own chance of this, stated with the estimate: 65%); the middle value lies on the limit itself.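

The step from compound 1 to compound 3 cannot be read, because both compounds stop at a limit in this assay: the limit of > 100000 nM in this assay, at which 3 of the 3 values shown sit. The compounds shown leave open how strongly any of them acts on these cells, and whether changing groups on the shared core alters that at all.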